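This account rests on a few compounds, and the source may have more. Where it says the series, first, only, none or still open, it means among the compounds named here.

Measured compounds in a functional assay on HCT-116 cells (Homo sapiens) for inhibition, read by MTT assay, with a stated time of 48 h; a lower number here means a stronger inhibitor, a higher number a weaker inhibitor:
- compound 1, `Brc1ccccc1CSc1nnc(-c2ccncc2)n1-c1ccccc1`: 20200 nM
- compound 2, `c1ccc(CSc2nnc(-c3ccncc3)n2-c2ccccc2)cc1`: 16900 nM

Among the compounds with values here, compound 2 sits at one end of the two measured numbers, but its only neighbour is compound 1 and the step of a 1.2-fold lower number from compound 1 to compound 2 (0.08 log units; within the scatter) does not separate them beyond the scatter. The next step goes from compound 2 to compound 3, `O=[N+]([O-])c1ccc(CSc2nnc(-c3ccncc3)n2-c2ccccc2)cc1`, which is not yet measured in this assay. The change is nitro in place of hydrogen on an aromatic carbon. Within the data shown here, the single step measured so far, a 1.2-fold lower number from compound 1 to compound 2 (0.08 log units; within the scatter), also concerns a substituent on the same six-membered carbon ring of the benzyl group, and it shows no effect beyond the scatter; it is the only step that bears on the present one, and it involves a different group at a different place. On that basis no shift beyond the scatter is expected, with the step of a 1.1-fold lower number from compound 2 to compound 3 (0.05 log units; within the scatter) taken as the expectation. Compound 3 is accordingly estimated at 15000 nM, in a range from 5000 nM to 45000 nM.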

Compound 3, half-maximal inhibitory concentration: 23800 nM
Estimate against measurement, compound 3: 1.6-fold (0.20 log units) below; measured number inside the range.
By their numbers in this assay, from the lowest: compounds 2, 1 and 3 (each within the scatter of the next).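

In this assay, nitro in place of hydrogen, on the aromatic carbon para to a large group, gives a 1.4-fold higher number from compound 2 to compound 3 (0.15 log units; within the scatter), so the change from phenyl to 4-nitrophenyl, which adds 3 heavy atoms at this place, does not separate the pair beyond the scatter. Exchanging 2-bromophenyl for 4-nitrophenyl gives a 1.2-fold higher number from compound 1 to compound 3 (0.07 log units; within the scatter), so the exchange of both group and place on this ring also stays within the scatter, and the three compounds cannot be ranked. Nothing measured here explains this result.

On these data alone, whether an amine or a carboxylic acid at the same aromatic carbon would move the number beyond the scatter remains open. Also open, as far as these compounds go, is what a longer chain in place of the saturated chain carbon bound to the sulfur, or any change elsewhere in the shared core, would do.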